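A Dimethoxyphenyl Arm on the Shared Core

A few compounds are considered here, and "the series" means these few. Any claim that something is new, unique, unknown or untested is made for them only; others in the source may bear on it.

Of the compounds shown here, three have so far been measured in a functional assay on HCT-15 cells (Homo sapiens) for antiproliferative activity, with a stated time of 48 h; a higher number here means that more compound is tolerated, a lower number that less compound is tolerated. Compound 1 `Cc1cc(O)c(C2=NN(c3ccc(S(N)(=O)=O)cc3)C(c3ccccc3O)C2)cc1Cl` gives 44700 nM. Compound 2 `Cc1cc(O)c(C2=NN(c3ccc(S(N)(=O)=O)cc3)C(c3ccccc3Cl)C2)cc1Cl` reaches only the limit of the assay, > 100000 nM. Compound 3 `Cc1cc(O)c(C2=NN(c3ccc(S(N)(=O)=O)cc3)C(/C=C/c3ccccc3)C2)cc1Cl` likewise sits at the assay limit, > 100000 nM, so for compound 3 only a limit and no number is known, a position it shares with one other value (the limit of > 100000 nM in this assay, at which 2 of the 3 values shown sit). The step of an at least 2.2-fold higher number from compound 1 to compound 2 (0.34 log units; beyond the scatter) and the step of an at least 2.2-fold higher number from compound 1 to compound 3 (0.34 log units; beyond the scatter) both run upward, while the step that the two limits leave unreadable from compound 2 to compound 3 cannot be read because both ends are limits.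

Compound 4 `COc1ccc(C2CC(c3cc(Cl)c(C)cc3O)=NN2c2ccc(S(N)(=O)=O)cc2)cc1OC` differs from compound 3 in one place: 3,4-dimethoxyphenyl in place of 2-phenylethenyl on a saturated ring carbon. For the measured compounds named here, the measured steps that touch this position are the one from compound 1 to compound 3 and the unreadable one from compound 2 to compound 3; neither involves a dimethoxyphenyl, and the nearest measured neighbour at this position, compound 1 with its 2-hydroxyphenyl, gives 44700 nM. The step of an at least 1.1-fold lower number from compound 3 to compound 4 (0.04 log units; that floor lies within the scatter) is therefore expected to be of no clear size beyond the scatter. The estimate for compound 4 is 90000 nM, between 35000 nM and 250000 nM, with a fair chance that this assay again reports only a limit.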

Compound 4, concentration lethal to 50% of the cells: > 100000 nM
Compound 4 ended at the assay's limit; the forecaster's own chance of this, stated with the estimate: 55%; at least 1.1-fold (0.04 log units) between middle value and limit.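

In this assay, the change from 2-hydroxyphenyl to 3,4-dimethoxyphenyl on the saturated ring carbon gives an at least 2.2-fold higher number from compound 1 to compound 4 (0.34 log units; beyond the scatter), the same direction as the two earlier changes away from compound 1. For the compounds shown here, this makes 3,4-dimethoxyphenyl the third group at this position to end at the limit, and the first with two hydrogen-bond acceptors and no chlorine or double bond outside aromatic rings, so compound 1 with its 2-hydroxyphenyl is now the only one of the four compounds with a number, and none of the four goes against this: the limit of > 100000 nM in this assay, at which 3 of the 4 values shown sit. The steps among compounds 2, 3 and 4 cannot be read, as both ends of each are limits, so nothing orders the 2-chlorophenyl, 2-phenylethenyl and 3,4-dimethoxyphenyl groups against one another.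

The compounds shown leave open how far each of these three lies past the limit, and whether the hydroxy on the phenyl group of compound 1 is itself what sets it apart. A phenyl group carrying an amine or a carboxylic acid in place of that hydroxy would bear on the second question.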